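The source may hold more compounds than are shown below. What is called first, only, known or untested is meant among the compounds shown, and "the series" means these compounds.

Measured so far in a functional assay on NCI-H1650 cells (Homo sapiens) for cytotoxicity, read by MTT assay, with a stated time of 72 h; on this read-out lower numbers stand for stronger inhibition and higher numbers for weaker inhibition:
- Compound 1 `O=C1/C(=C/c2ccccc2F)COC/C1=C\c1ccc(Cl)cc1Cl` gives 8600 nM
- Compound 2 `O=C1/C(=C/c2ccccc2F)COC/C1=C\c1ccccc1C(=O)O` gives 15200 nM

Compound 2 stands at 15200 nM and lies within the usual scatter of compound 1 (8600 nM), so these two numbers do not separate the pair. Compound 3 `O=C1/C(=C/c2ccccc2F)COC/C1=C\c1ccccc1Br` has not yet been measured in this assay and shares the core of compound 2. It carries bromo in place of carboxy on an aromatic carbon, ortho to a large group (bromo in place of carboxy on an aromatic carbon). For the measured compounds named here, no measured pair isolates this change, so the data offer no direct step to lean on. Compound 1, which has halogen rather than carboxy on that ring, gives 8600 nM and is the nearest guide, suggesting a number of similar size. No change beyond the scatter is expected, and a 1.9-fold lower number from compound 2 to compound 3 (0.28 log units; within the scatter) is estimated to stay within it, leaning slightly toward a lower number. Compound 3 is estimated at 8000 nM with a range of 3000 nM to 18000 nM (expected, not measured).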

Compound 3, half-maximal inhibitory concentration: 6500 nM
Compound 3: middle estimate off by 1.2-fold (0.09 log units), on the high side; the measured number falls inside the stated range.
By their numbers in this assay, from the lowest: compounds 3, 1 and 2 (each within the scatter of the next, the first and the last beyond it).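

In this assay, for the compounds shown here, putting bromo in place of carboxy on an aromatic carbon, ortho to a large group, gives the first step in this set that clears the scatter: a 2.3-fold lower number from compound 2 to compound 3 (0.37 log units; beyond the scatter), a modest change. Compound 1 and compound 2 had stayed within the scatter of each other, so until now no difference at this ring could be read. The step for 2-bromophenyl in place of 2,4-dichlorophenyl on a double-bonded chain carbon bound to a double-bonded ring carbon is a 1.3-fold lower number from compound 1 to compound 3 (0.12 log units; within the scatter), which leaves the two halogen-bearing compounds unseparated, and compound 2 stands apart only from compound 3, not from compound 1. Nothing at hand gives a reason for the step from carboxy to bromo.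

Going by these compounds, what stays open is whether that step reflects the loss of carboxy or the arrival of bromo, a question that a plain hydrogen, an amine or a methoxy group on the same aromatic carbon would bear on. On these data alone, whether the step would hold with a different group on the other aromatic ring of the shared core also remains unknown.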